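This account rests on a few compounds, and the source may have more. Where it says the series, first, only, none or still open, it means among the compounds named here.

Working notes on the series in a functional assay on HL-60 cells (Homo sapiens) for cytotoxicity, read by CCK-8 assay, with a stated time of 24 h; on this read-out lower numbers stand for stronger inhibition and higher numbers for weaker inhibition. Compound 1 `C=CC(=O)N1C(=O)CC(c2ccc(C(F)(F)F)cc2)Sc2ccccc21` gives 106000 nM, compound 2 `C=CC(=O)N1C(=O)CC(c2ccc(C)cc2)Sc2ccccc21` gives 94400 nM, and compound 3 `C=CC(=O)N1C(=O)CC(c2ccc(Cl)cc2)Sc2ccccc21` gives 95700 nM. Compound 3 therefore stands level with the other two, its value lying within the scatter of both.

The next structure, compound 4 `C=CC(=O)N1C(=O)CC(c2ccc([N+](=O)[O-])cc2)Sc2ccccc21`, has nitro in place of chloro on an aromatic carbon, para to a large group: nitro in place of chloro on an aromatic carbon.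

Going by the values given here, three measured steps bear on this change, each an exchange on that same aromatic carbon: a 1.1-fold lower number from compound 1 to compound 2 (0.05 log units; within the scatter), a 1.1-fold lower number from compound 1 to compound 3 (0.04 log units; within the scatter) and a 1.0-fold higher number from compound 2 to compound 3 (0.01 log units; within the scatter). All three lie within the scatter, so trifluoromethyl, methyl and chloro cannot be told apart here. No nitro comparison exists yet, and the series holds only these three values. No step beyond the scatter is therefore expected in this assay, starting from compound 3 at 95700 nM. The expected outcome is a 1.0-fold lower number from compound 3 to compound 4 (0.02 log units; within the scatter). The estimate for compound 4 is 92000 nM, with an expected range of 52000 nM to 145000 nM.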

Compound 4, half-maximal inhibitory concentration: 107000 nM
The estimate for compound 4 lay 1.2-fold (0.07 log units) below the measured number, and the stated range covers the measured number.
By their numbers in this assay, from the lowest: compounds 2, 3, 1 and 4 (each within the scatter of the next).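

In this assay the nitro exchange gives a 1.1-fold higher number from compound 3 to compound 4 (0.05 log units; within the scatter) and a 1.1-fold higher number from compound 2 to compound 4 (0.05 log units; within the scatter) and a 1.0-fold higher number from compound 1 to compound 4 (0.00 log units; within the scatter) so the earlier flat picture now extends to a group with more heavy atoms and with hydrogen-bond acceptors. On this aromatic carbon, para to a large group, trifluoromethyl, methyl, chloro and nitro cannot be told apart, and the exchange of chloro for nitro brings no step beyond the scatter. No measurement in hand explains this flatness.

From the compounds shown here alone, whether this position can shift the number at all remains open, since all four compounds share the same level. An amine or a carboxylic acid on this carbon could test that, and whether changes elsewhere on the shared core matter more also stays unanswered.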